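The compounds below may be only part of what the source reports. "The series", "measured", "known", "first", "only" and "open" are said of these compounds alone.

Compound 1 `O=C1C(Nc2ccc(I)cc2)=CC(=O)c2c1nc1n2[C@H]2OC[C@@H](O)[C@H]2OC1`: in a functional assay on HeLa cells (Homo sapiens) for inhibition, read by sulforhodamine B assay (a higher number here means a weaker inhibitor, a lower number a stronger inhibitor), compound 1 gives 4010 nM.
Compound 2 `O=C1C=C(Nc2cccc(F)c2)C(=O)c2c1nc1n2[C@H]2OC[C@@H](O)[C@H]2OC1`: compound 2 gives 6440 nM.
Compound 3 `O=C1C(Nc2ccc(C(F)(F)F)cc2)=CC(=O)c2c1nc1n2[C@H]2OC[C@@H](O)[C@H]2OC1`: compound 3 gives 8920 nM.

Compound 2 sits between the other two on these numbers, within the scatter of both. Compound 4 `Cc1ccc(NC2=CC(=O)c3nc4n(c3C2=O)[C@H]2OC[C@@H](O)[C@H]2OC4)cc1` differs from it by 4-methylphenyl in place of 3-fluorophenyl on an amine nitrogen. Among the measured compounds shown here, the only measured step, a 2.2-fold higher number from compound 1 to compound 3 (0.35 log units; beyond the scatter), swaps two other groups on the ring and does not mirror this change, so there is no direct guide. The three measured values stay close together, which suggests the change to compound 4 is expected to give a step of about a 1.2-fold lower number from compound 2 to compound 4 (0.07 log units; within the scatter), not clearly beyond the scatter. Compound 4 is therefore estimated at 5500 nM, with a likely range of 2500 nM to 12000 nM.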

Compound 4, half-maximal inhibitory concentration: 3860 nM
The estimate for compound 4 lay 1.4-fold (0.15 log units) above the measured number; low and high end bracket the measured number.
By their numbers in this assay, from the lowest: compounds 4, 1, 2 and 3 (each within the scatter of the next, the first and the last beyond it).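

In this assay, 4-methylphenyl in place of 3-fluorophenyl on the amine nitrogen gives a 1.7-fold lower number from compound 2 to compound 4 (0.22 log units; within the scatter). The earlier compounds shown here all carried iodine or fluorine on this ring, whereas compound 4 carries neither, so a ring of carbon only is compatible with this position. This single step swaps the group and moves it around the ring at once, so the two changes cannot be told apart. An amine or a carboxylic acid on this ring remains untested in the compounds shown. Nothing available here explains why this step stays within the scatter.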